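The source may hold more compounds than are shown below. What is called first, only, known or untested is meant among the compounds shown, and "the series" means these compounds.

Measured so far:
- compound 1, `CC1CCN(C2CCN(S(=O)(=O)c3cccc(-c4ccc(F)cc4)c3)CC2)CC1`: 12 nM
- compound 2, `CC1CCN(C2CCN(S(=O)(=O)c3ccc(F)cc3F)CC2)CC1`: 102 nM
- compound 3, `Cc1ccc(C#N)c(S(=O)(=O)N2CCC(N3CCC(C)CC3)CC2)c1`: 285 nM

In a functional assay on DLD-1 cells (Homo sapiens) for antiproliferative activity, read by CellTiter-Glo, with a stated time of 72 h (on this read-out higher numbers stand for weaker inhibition and lower numbers for stronger inhibition), compound 1 gives 12 nM, the lowest number of the three. Compound 2 sits higher at 102 nM and compound 3 higher still at 285 nM; both gaps lie beyond the scatter of repeated measurements, so compound 1 is the most potent of the measured set. Within the data shown here, compounds 2 and 3 carry different aryl sulfonyl parts on the shared core and are not single-point neighbours of compound 1, so no step between them is counted here.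

The next compound, compound 4, `CC1CCN(C2CCN(S(=O)(=O)c3cccc(-c4ccccc4)c3)CC2)CC1`, differs from compound 1 in one place: hydrogen in place of fluoro on an aromatic carbon. The fluorine leaves and a hydrogen takes its place on the outer ring of the biaryl. Among the measured compounds shown here, no measured pair isolates this change, so the expectation rests on the general run of such small edits. The step from compound 1 to compound 4 is expected to be small, a 1.7-fold higher number from compound 1 to compound 4 (0.22 log units; within the scatter), and to fall within or just beyond the usual scatter, with a slight lean toward a weaker number. Compound 4 is therefore estimated at 20 nM in this assay, in a range from 6 nM to 65 nM.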

Compound 4, half-maximal inhibitory concentration: 2 nM
Beside the measured number, compound 4's estimate is 10-fold (1.00 log units) above it; measured number outside the range, below it.
By their numbers in this assay, from the lowest: compound 4; then compound 1; then compound 2; then compound 3.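

In this assay, the outer ring of the biaryl proves sensitive to a single atom: the change from 4-fluorophenyl to phenyl gives a 6.0-fold lower number from compound 1 to compound 4 (0.78 log units; beyond the scatter). This aromatic carbon, para to a large group, therefore has a measurable effect on potency, and here the fluoro group is the less favourable of the two substituents compared. Nothing available explains this gain, so the cause remains unassigned.

From the compounds shown here alone, only hydrogen and fluoro have been compared at this carbon, so it remains open whether chloro, methoxy or an amine would match hydrogen or fall closer to fluoro. Going by these compounds, it is also open whether the same fluoro-to-hydrogen change would give a similar step with a different aryl sulfonyl part or elsewhere on the outer ring.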